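The source may report more compounds than this note shows. Statements on the series, on what has been measured and on what is new or still open speak of the compounds shown alone.

- compound 1 `O=C(NCc1cc(Cl)ccc1-n1cnnn1)[C@@H]1CC=NN1C(=O)[C@H](O)c1ccccc1F`: 8.9 10^-6 cm/s
- compound 2 `O=C(NCc1cc(Cl)ccc1-n1cnnn1)[C@@H]1[C@@H]2C[C@@H]2CN1C(=O)[C@H](O)Cc1ccccn1`: 0.62 10^-6 cm/s
- compound 3 `O=C(NCc1cc(Cl)ccc1-n1cnnn1)[C@@H]1CC=NN1C(=O)[C@H](O)c1ccccc1`: 7 10^-6 cm/s

These values come from an ADME assay on Caco-2 cells (Homo sapiens) for permeability, read by LC-MS, in the apical to basolateral direction, with a stated time of 60 min, at pH 6.5; a higher number here means that the compound crosses the layer faster, a lower number that the compound crosses the layer more slowly. Compound 2 has the lowest number of the three, at 0.62 10^-6 cm/s, well under compound 3 at 7 10^-6 cm/s and compound 1 at 8.9 10^-6 cm/s. Compound 4 `COC(C)(C)[C@@H](O)C(=O)N1C[C@H]2C[C@H]2[C@H]1C(=O)NCc1cc(Cl)ccc1-n1cnnn1` keeps the core of compound 2 and carries 1-methoxy-1-methylethyl in place of (pyridin-2-yl)methyl on a saturated chain carbon bound to a carbonyl carbon and an oxygen on a saturated carbon.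

Among the measured compounds shown here, no measured step makes this exchange. For the measured compounds named here, the only step available is a 1.3-fold lower number from compound 1 to compound 3 (0.10 log units; within the scatter), which lies within the scatter and concerns hydrogen in place of fluoro on an aromatic carbon, so it bears only weakly. Compound 2 alone carries the (pyridin-2-yl)methyl group, but its core also differs from the other two, and the data cannot separate these features. A modest rise is therefore expected, with the estimate anchored on compound 2 at 0.62 10^-6 cm/s. The expected change is a 1.9-fold higher number from compound 2 to compound 4 (0.29 log units; within the scatter). The estimated value for compound 4 is 1.2 10^-6 cm/s, with an expected range from 0.4 10^-6 cm/s to 4 10^-6 cm/s.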

Compound 4, apparent permeability: 3.5 10^-6 cm/s
Beside the measured number, compound 4's estimate is 2.9-fold (0.46 log units) below it; the measured number falls inside the stated range.
By their numbers in this assay, from the lowest: compound 2; then compounds 4, 3 and 1 (each within the scatter of the next, the first and the last beyond it).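

On the saturated chain carbon bound to a carbonyl carbon and an oxygen on a saturated carbon, with the core of compound 2 kept, 1-methoxy-1-methylethyl in place of (pyridin-2-yl)methyl gives a 5.6-fold higher number from compound 2 to compound 4 (0.75 log units; beyond the scatter) in this assay and is the only step shown at this position. Among the compounds shown here, compound 4 carries that same core, so the low number of compound 2 does not belong to the core alone, a point the earlier compounds could not separate. No measurement shown bears on why the number moves.

The exchange removes a six-membered aromatic ring and brings in a chain with an ether oxygen, and the compounds shown do not tell these two changes apart. Going by these compounds, a benzyl or tert-butyl group on this carbon would bear on that question, and it remains open whether the exchange carries over to the core of compound 3.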